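This account rests on a few compounds, and the source may have more. Where it says the series, first, only, none or still open, it means among the compounds named here.

Compound 1 `O=S(=O)(Nc1ccc(-c2nc3ccccc3o2)cc1)c1cccs1`: > 63000 nM
Compound 2 `O=S(=O)(Nc1ccc(-c2nc3ccccc3o2)cc1)c1ccc(F)c(C(F)(F)F)c1`: > 63000 nM
Compound 3 `O=S(=O)(Nc1ccc2oc(-c3ccccc3)nc2c1)c1cccc(C(F)(F)F)c1`: > 63000 nM

All three values come from an assay on isolated protein for inhibition of malate dehydrogenase, mitochondrial (Sus scrofa), with stated times of 45 min and 30 min; a lower number here means a stronger inhibitor, a higher number a weaker inhibitor. For compound 1 the value > 63000 nM is a limit of the assay, not a measured number. The same holds for compound 2, whose value > 63000 nM is a limit. Compound 3 also gives only a limit, > 63000 nM. Because (the limit of > 63000 nM in this assay, at which 3 of the 3 values shown sit), compound 1 cannot be placed above or below its two companions on these numbers; all that is known is that none of the three showed measurable inhibition within the tested range.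

Compound 4 `Cc1cccc(S(=O)(=O)Nc2ccc(-c3nc4ccccc4o3)cc2)c1` has not yet been measured. It differs from compound 1 in one place: 3-methylphenyl in place of thiophen-2-yl on a sulfonyl sulfur. Within the data shown here, no measured step between two compounds exists here to guide the size or direction of this change, so the expectation for the step from compound 1 to compound 4 is no change beyond the usual scatter of this assay, and the estimated step is a step that the limit leaves unreadable from compound 1 to compound 4. For compound 4 the expected value in this assay is 100000 nM, with a range from 30000 nM to 300000 nM, most likely again reported only as a limit.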

Compound 4, half-maximal inhibitory concentration: > 63000 nM
Compound 4: only a limit was reported; the forecaster's own chance of this, stated with the estimate: 85%; the middle value does not contradict the limit.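

Compound 4 gives > 63000 nM, which is a limit and not a number. No step can be read between compound 1 and compound 4, because both values are limits: the limit of > 63000 nM in this assay, at which 4 of the 4 values shown sit.

The compounds shown leave open what structure, if any, would give a measurable value in this assay.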